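This account rests on a few compounds, and the source may have more. Where it says the series, first, only, none or still open, it means among the compounds named here.

Compound 1 `NC(=S)Nc1cccc(OCCCCCCc2ccccc2)c1` gives 28000 nM in an ADME assay on Ava5 cells (Homo sapiens) for cytotoxicity; a higher number here means that more compound is tolerated, a lower number that less compound is tolerated. Compound 2 `NC(=S)Nc1cccc(OCCCCCCCc2ccccc2)c1` gives 23000 nM in this assay. Compound 3 `NC(=S)Nc1cccc(OCCCCCOc2ccc(Br)cc2)c1` gives 19000 nM in this assay.

The three numbers lie close together: the steps of a 1.5-fold lower number from compound 1 to compound 3 (0.17 log units; within the scatter) and a 1.2-fold lower number from compound 2 to compound 3 (0.08 log units; within the scatter) are both within the scatter, so compound 3 is not set apart from the other two. The step of a 1.2-fold lower number from compound 1 to compound 2 (0.09 log units; within the scatter) is likewise within the scatter.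

Compound 4 `NC(=S)Nc1cccc(OCCCCCOc2ccc(-c3ccco3)cc2)c1` differs from compound 3 only at the far end of the chain: furan-2-yl in place of bromo on an aromatic carbon, on an aromatic carbon of a six-membered aromatic ring of carbon only, para to a large group. For the measured compounds named here, none of the measured steps changes a substituent on that terminal ring; all three exchange the whole end of the chain, and all three stay within the scatter. On that basis the expected step of a 1.1-fold lower number from compound 3 to compound 4 (0.05 log units; within the scatter) in this assay is none beyond the scatter, in either direction. Compound 4 is therefore estimated at 17000 nM in this assay, with a range from 8000 nM to 40000 nM.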

Compound 4, half-maximal cytotoxic concentration: 11000 nM
Compound 4: the middle estimate sits 1.5-fold (0.19 log units) above what was measured; the range from low to high includes it.
By their numbers in this assay, from the lowest: compounds 4, 3, 2 and 1 (each within the scatter of the next, the first and the last beyond it).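

This is the first step among these compounds that alters a substituent on the terminal ring itself, on the aromatic carbon para to a large group. There, a single bromine gives way to furan-2-yl, with 5 heavy atoms, a five-membered aromatic ring and a hydrogen-bond acceptor, yet this assay shows a 1.7-fold lower number from compound 3 to compound 4 (0.24 log units; within the scatter) and so does not separate the two compounds despite the added ring. Nothing measured here explains how this group acts at this position.

The compounds shown leave open whether an amine, a carboxylic acid or a methoxy group at this same place would also stay within the scatter of compound 3 in this assay or move clearly away from it. They also leave open whether furan-2-yl would behave the same way on a shorter chain.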